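A few compounds are considered here, and "the series" means these few. Any claim that something is new, unique, unknown or untested is made for them only; others in the source may bear on it.

Compound 1 `CC(=O)Nc1ccc([C@H](C)NCC2CCN(CCCc3c[nH]c4ccc(-n5cnnc5)cc34)CC2)cc1`: 9.3 nM
Compound 2 `CN(Cc1ccco1)C1CCN(CCCc2c[nH]c3ccc(-n4cnnc4)cc23)CC1`: 89 nM

Both numbers come from an assay on CHO cells for displacement of a labelled ligand from 5-hydroxytryptamine receptor 1B (Homo sapiens); a lower number here means a stronger inhibitor, a higher number a weaker inhibitor. Of the two measured compounds, compound 2 gives the higher number, meaning weaker binding, and the gap to compound 1 is beyond the usual scatter. Among the measured compounds shown here, no single-point step links these two, since they differ in more than one place, so only their two values can be set side by side.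

Compound 3 `c1ccc(NCC2CCN(CCCc3c[nH]c4ccc(-n5cnnc5)cc34)CC2)nc1` has not yet been measured. It shares the core of compound 2 and differs from it in one place: ((pyridin-2-yl)amino)methyl in place of ((furan-2-yl)methyl)(methyl)amino on a saturated ring carbon. The group that leaves carries no hydrogen-bond donor, the group that enters carries one. A modest improvement is expected, partly because compound 1, which also bears a hydrogen-bond donor in the corresponding group, gives 9.3 nM. The expected step is a 2.5-fold lower number from compound 2 to compound 3 (0.41 log units; beyond the scatter), a drop in the number near the edge of the scatter. Compound 3 is therefore estimated at 35 nM, with a likely range from 8 nM to 150 nM.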

Compound 3, half-maximal inhibitory concentration: 3.3 nM
The estimate for compound 3 lay 11-fold (1.03 log units) above the measured number, and the stated range ends above it.
By their numbers in this assay, from the lowest: compound 3; then compound 1; then compound 2.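

In this assay, the step with ((pyridin-2-yl)amino)methyl in place of ((furan-2-yl)methyl)(methyl)amino is a 27-fold lower number from compound 2 to compound 3 (1.43 log units; beyond the scatter), so this saturated ring carbon responds strongly to the group it carries, even when the entering and leaving groups have the same number of heavy atoms. With pyridin-2-yl in place of 1-(4-acetamidophenyl)ethyl on the amine nitrogen, the step is a 2.8-fold lower number from compound 1 to compound 3 (0.45 log units; beyond the scatter), so the 1-(4-acetamidophenyl)ethyl group is not needed for strong binding here. No independent data explain why either step occurs.

The change from compound 2 to compound 3 alters the aromatic ring, the linking atoms and the hydrogen-bond donor count together, so their separate contributions cannot be told apart. The compounds shown also leave open how a plain phenyl ring in place of pyridin-2-yl, or a methyl group on the linking amine nitrogen, would affect binding.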